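The compounds below may be only part of what the source reports. "The series", "measured", "known", "first", "only" and "open" are said of these compounds alone.

Measured so far:
compound 1 `Nc1ncnc2c1ncn2[C@@H]1O[C@H](CSCC[C@H](N)C(=O)NCc2ccccc2)[C@@H](O)[C@H]1O`: 120000 nM
compound 2 `CCn1cc(CNC(=O)[C@@H](N)CCSC[C@H]2O[C@@H](n3cnc4c(N)ncnc43)[C@H](O)[C@@H]2O)cn1`: 50000 nM

Both were tested in an assay on Sf9 cells for inhibition of histone-lysine N-methyltransferase EZH2 (Homo sapiens), read by scintillation counting, in the presence of a further agent that is not named here; a lower number here means a stronger inhibitor, a higher number a weaker inhibitor. Among the measured compounds shown here, compound 2 gives the lower of the two numbers; its only neighbour is compound 1, and the step of a 2.4-fold lower number from compound 1 to compound 2 (0.38 log units; beyond the scatter) is modest but beyond the scatter. Compound 3 `Cc1ccccc1-n1cc(CNC(=O)[C@@H](N)CCSC[C@H]2O[C@@H](n3cnc4c(N)ncnc43)[C@H](O)[C@@H]2O)cn1` has not yet been measured. It differs from compound 2 in one place: 2-methylphenyl in place of ethyl on an aromatic nitrogen, on the five-membered aromatic ring with 2 nitrogen. For the measured compounds named here, no measured step concerns a change on that ring nitrogen; the single known step of a 2.4-fold lower number from compound 1 to compound 2 (0.38 log units; beyond the scatter) alters a different part of the molecule, so it bears only loosely on this change, showing that this region of compound 2 tolerates alteration. The expected step in this assay is therefore a 1.3-fold lower number from compound 2 to compound 3 (0.10 log units; within the scatter), within the scatter, with no direction claimed. Compound 3 is expected to give 40000 nM, with a range from 15000 nM to 130000 nM.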

Compound 3, half-maximal inhibitory concentration: 28000 nM
Compound 3: the middle estimate sits 1.4-fold (0.15 log units) above what was measured, and the stated range covers the measured number.
By their numbers in this assay, from the lowest: compounds 3 and 2 (each within the scatter of the next); then compound 1.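

In this assay, the ring nitrogen takes a far larger group, 2-methylphenyl with 7 heavy atoms in place of ethyl with 2, and the result is a 1.8-fold lower number from compound 2 to compound 3 (0.25 log units; within the scatter), so this added bulk brings no change that can be read beyond normal assay noise. Seen as a single replacement of the phenyl in compound 1, the whole group now present in compound 3 gives a 4.3-fold lower number from compound 1 to compound 3 (0.63 log units; beyond the scatter), a modest gain that is clearer than the step from ethyl to 2-methylphenyl alone. Nothing given here explains either step.
The compounds shown cannot separate the contribution of the new aromatic ring from that of its methyl group. On these data alone, it also remains open what a plain phenyl, or a group carrying an amine or a carboxylic acid, would do on that ring nitrogen.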